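The compounds below may be only part of what the source reports. "The series", "measured", "known", "first", "only" and "open" are said of these compounds alone.

Measured so far:
compound 1 `CCO/C(O)=C1\C(COCCN2CC(=O)N(C)C2=O)=NC(C)=C(C(=O)OC)C1c1cccc(Cl)c1Cl` — in a functional assay (aorta) with Rattus norvegicus as the target (on this read-out higher numbers stand for weaker inhibition and lower numbers for stronger inhibition), compound 1 gives 5.01 nM
compound 2 `CCO/C(O)=C1\C(COCCn2ccnn2)=NC(C)=C(C(=O)OC)C1c1ccccc1Cl` — in this assay compound 2 gives 15.9 nM

Among the compounds with values here, of the two, compound 2 gives the higher number and compound 1 the lower; the two structures differ in more than one place, so no single step is read from them. Compound 3 `CCO/C(O)=C1\C(COCCN2CC(=O)N(C)C2=O)=NC(C)=C(C(=O)OC)C1c1ccccc1Cl` is not yet measured. It is obtained from compound 2 by 3-methyl-2,4-dioxoimidazolidin-1-yl in place of 1H-1,2,3-triazol-1-yl on a saturated chain carbon, two bonds along the chain from an oxygen on a saturated carbon. Within the data shown here, compound 1 carries the same entering group and gives 5.01 nM, which is the only guide. The step of a 1.8-fold lower number from compound 2 to compound 3 (0.25 log units; within the scatter) is expected to be modest and toward a lower number, not clearly beyond the scatter. For compound 3 the estimate in this assay is 9 nM, within 3 nM to 25 nM.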

Compound 3, half-maximal inhibitory concentration: 25.1 nM
The estimate for compound 3 lay 2.8-fold (0.45 log units) below the measured number; the measured number lies above the stated range.
By their numbers in this assay, from the lowest: compound 1; then compounds 2 and 3 (each within the scatter of the next).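

In this assay, 3-methyl-2,4-dioxoimidazolidin-1-yl in place of 1H-1,2,3-triazol-1-yl on this saturated chain carbon gives a 1.6-fold higher number from compound 2 to compound 3 (0.20 log units; within the scatter) and so does not separate the two rings. Hydrogen in place of chloro on an aromatic carbon gives a 5.0-fold higher number from compound 1 to compound 3 (0.70 log units; beyond the scatter) and, of the two steps, is the only one beyond the scatter. Nothing available explains either step.

Going by these compounds, an amine or a carboxylic acid in place of these rings at the end of the ethoxy chain remains open. On these data alone, whether the chloro step keeps its size with 1H-1,2,3-triazol-1-yl on the chain also remains open.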